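Swapping bromo for isopropoxy: compound 2 to compound 4

The compounds below may be only part of what the source reports. "The series", "measured", "known", "first", "only" and "open" are said of these compounds alone.

Measured in a functional assay on Hs68 cells (Homo sapiens) for cytotoxicity; a lower number here means that less compound is tolerated, a higher number that more compound is tolerated:
- compound 1 `CC(C)Oc1ccccc1CNC(=O)c1ccc2cncc(Br)c2n1`: 9 ug/mL
- compound 2 `O=C(NCc1cccc(Br)c1)c1ccc2cnccc2n1`: 50 ug/mL
- compound 3 `O=C(NCc1ccc(Br)cc1)c1ccc2cnccc2n1`: 10 ug/mL

Compound 2 holds the highest number of the three in this assay. Compound 4 `CC(C)Oc1cccc(CNC(=O)c2ccc3cnccc3n2)c1` differs from it in one place: isopropoxy in place of bromo on an aromatic carbon, meta to a large group. Among the measured compounds shown here, the only measured step is a 5.0-fold lower number from compound 2 to compound 3 (0.70 log units; beyond the scatter). That step relocates the bromo rather than replacing it, so it bears on the change only indirectly. Differing from compound 2 in more than one place, compound 1 also carries isopropoxy and gives 9 ug/mL. A step no larger than that modest one is therefore expected, towards a lower number. The expected change is a 1.7-fold lower number from compound 2 to compound 4 (0.22 log units; within the scatter). For compound 4 the estimate is 30 ug/mL, with an expected range from 10 ug/mL to 90 ug/mL.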

Compound 4, half-maximal cytotoxic concentration: 8.4 ug/mL
Compound 4: middle estimate off by 3.6-fold (0.55 log units), on the high side; the measured number lies below the stated range.
By their numbers in this assay, from the lowest: compounds 4, 1 and 3 (each within the scatter of the next); then compound 2.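

Measured in this assay there is a 6.0-fold lower number from compound 2 to compound 4 (0.77 log units; beyond the scatter) so the high number of compound 2 does not hold when isopropoxy replaces bromo at this position. Among the compounds shown here, earlier, the only single change seen was a shift of the bromo, with a 5.0-fold lower number from compound 2 to compound 3 (0.70 log units; beyond the scatter) and this step shows that exchanging the group itself also lowers the number. Nothing available here explains the drop.

From the compounds shown here alone, whether chloro, methoxy or an amine at this same place would keep the number of compound 2 stays open. So does whether any group other than bromo would do so.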